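This account rests on a few compounds, and the source may have more. Where it says the series, first, only, none or still open, it means among the compounds named here.

Going by the values given here, in a physicochemical assay for lipophilicity, measured as octanol-water partition (on this read-out lower numbers stand for lower lipophilicity and higher numbers for higher lipophilicity), compound 1 `C/C(=N\NC(=O)COc1cccc2ccccc12)c1cccc([N+](=O)[O-])c1` gives 3.37, the lower of the two numbers so far and beyond the scatter from compound 2 `O=C(COc1cccc2ccccc12)N/N=C/c1ccc(Br)cc1`, which gives 4.81. Compound 3 `C/C(=N\NC(=O)COc1cccc2ccccc12)c1ccc(Br)cc1` is still unmeasured. Its difference from compound 1 is 4-bromophenyl in place of 3-nitrophenyl on a carbon with a double bond to nitrogen, with 4-bromophenyl in place of 3-nitrophenyl on a carbon with a double bond to nitrogen. Among the compounds with values here, no measured pair isolates this change, so the only guide is compound 2, which also carries 4-bromophenyl and stands at 4.81. An upward move beyond the scatter is expected, a number 1.23 log units higher from compound 1 to compound 3 (beyond the scatter). For compound 3 the estimated value is 4.6, with an expected range from 4.1 to 5.1.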

Compound 3, partition coefficient: 3.61
Compound 3: the middle estimate sits 0.99 log units above what was measured; measured number below the stated range.
By their numbers in this assay, from the lowest: compounds 1 and 3 (each within the scatter of the next); then compound 2.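

In this assay, 4-bromophenyl in place of 3-nitrophenyl on a carbon with a double bond to nitrogen gives a number 0.24 log units higher from compound 1 to compound 3 (within the scatter), so at this position the two groups are not separated. Carrying 4-bromophenyl is therefore not enough for a number like that of compound 2 (4.81). Nothing at hand accounts for this result.

Still open, going by these compounds, is whether an amine or a carboxylic acid on this carbon would move the number beyond the scatter. Also open, on these data alone, is what a longer chain in place of the saturated chain carbon would give.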